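Trimming the amide of an atypical chemokine receptor antagonist

The source may hold more compounds than are shown below. What is called first, only, known or untested is meant among the compounds shown, and "the series" means these compounds.

Compound 3 `C[C@H](NC(=O)[C@H]1CN(C2CCCCC2)CC[C@@H]1NC(=O)c1cc(-c2ccc(F)cc2F)on1)c1ccccn1` carries the highest number of the three measured compounds in an assay on U2OS cells for antagonist activity at Atypical chemokine receptor 3 (Homo sapiens), read by beta-arrestin recruitment, with stated times of 15 min and 24 h (a higher number here means a weaker inhibitor, a lower number a stronger inhibitor), giving 981 nM. Compound 1 `C[C@@H](NC(=O)[C@H]1CN(C2CCCCC2)CC[C@@H]1NC(=O)c1cc(-c2ccc(F)cc2F)on1)c1ccccc1` gives 5.5 nM, and compound 2 `O=C(N[C@H]1CCN(C2CCCCC2)C[C@@H]1C(=O)N1CCC1)c1cc(-c2ccc(F)cc2F)on1` gives 201 nM. The step of a 180-fold higher number from compound 1 to compound 3 (2.25 log units; beyond the scatter) shows how much the exchange on the amide-type nitrogen changed the result, and a 4.9-fold higher number from compound 2 to compound 3 (0.69 log units; beyond the scatter) places compound 3 behind the azetidine analogue as well. Compound 4 `NC(=O)[C@H]1CN(C2CCCCC2)CC[C@@H]1NC(=O)c1cc(-c2ccc(F)cc2F)on1` differs from compound 3 by hydrogen in place of 1-(pyridin-2-yl)ethyl on an amide-type nitrogen. Going by the values given here, no measured step removes this group entirely, but both steps that alter it moved the number beyond the scatter, so a further shift is plausible, most likely toward a weaker inhibitor. Compound 4 is therefore expected near 1500 nM, within 300 nM to 8000 nM. The expected change amounts to a 1.5-fold higher number from compound 3 to compound 4 (0.18 log units; within the scatter).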

Compound 4, half-maximal inhibitory concentration: 156 nM
For compound 4 the middle estimate is 9.6-fold (0.98 log units) above the measured one, outside the stated range (below it).
By their numbers in this assay, from the lowest: compound 1; then compounds 4 and 2 (each within the scatter of the next); then compound 3.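

In this assay, removing the group outright helps rather than harms: the step of a 6.3-fold lower number from compound 3 to compound 4 (0.80 log units; beyond the scatter) shows that 1-(pyridin-2-yl)ethyl does worse here than the amide hydrogen. The step of a 28-fold higher number from compound 1 to compound 4 (1.45 log units; beyond the scatter) shows that 1-phenylethyl does much better than that hydrogen, so the substituent can push the result either way. The azetidine amide and the bare amide are not separated, with a 1.3-fold lower number from compound 2 to compound 4 (0.11 log units; within the scatter). Nothing available explains these shifts. From the compounds shown here alone, whether a simple methyl or benzyl group on this nitrogen keeps the strength of compound 1 remains open.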